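This account rests on a few compounds, and the source may have more. Where it says the series, first, only, none or still open, it means among the compounds named here.

Three amides have been measured in an assay on microsomes from intestine for inhibition of acyl-CoA:cholesterol acyltransferase (Oryctolagus cuniculus); a higher number here means a weaker inhibitor, a lower number a stronger inhibitor. Compound 1 `CCCCCCCC/C=C/CCCCCCCC(=O)Nc1ccccc1CC` gives 1200 nM, and compound 2 `CCCCCCCC/C=C/CCCCCCCC(=O)Nc1ccccc1C(C)C` gives 600 nM; the only difference between the two is a methyl on a chain carbon, and that step, a 2.0-fold lower number from compound 1 to compound 2 (0.30 log units; within the scatter), stays within the scatter. Compound 3 `CCCCCCCCCCC(C)(C)C(=O)Nc1c(O)cc(OC)cc1OC` carries a different, branched chain and a differently substituted ring, and in this assay compound 3 gives 590 nM, the lowest number of the three: it sits within the scatter of compound 2, yet lower than compound 1 by more than the scatter. Compound 4 `CCCCCCCCCCC(C)(C)C(=O)Nc1c(OC)cc(OC)cc1OCC(=O)O` has not been measured. It differs from compound 3 only by carboxymethyl in place of hydrogen on an oxygen on an aromatic ring. Within the data shown here, no measured step touches a substituent on the ring; the one measured step concerns a chain carbon and fell within the scatter, so it offers no guidance on direction or size here. Lacking a comparable step, the expectation for compound 4 is a step of a 1.2-fold higher number from compound 3 to compound 4 (0.07 log units; within the scatter), with no direction favoured beyond the scatter. Compound 4 is therefore estimated at 700 nM, within a range from 200 nM to 2500 nM.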

Compound 4, half-maximal inhibitory concentration: > 10000 nM
Compound 4: only a limit was reported; the forecaster's own chance of this, stated with the estimate: 10%; middle value at least 14-fold (1.15 log units) from the limit.
By their numbers in this assay, from the lowest: compounds 3, 2 and 1 (each within the scatter of the next, the first and the last beyond it). At a limit, above all of these: compound 4.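

Among these compounds, this is the first change at the oxygen on the aromatic ring, and in this assay it is large: an at least 16-fold higher number from compound 3 to compound 4 (1.22 log units; beyond the scatter). Unlike the one earlier step, which concerned a chain carbon and stayed within the scatter, this result shows that the hydrogen on this oxygen cannot be swapped for carboxymethyl without a clear loss of inhibition. Compound 4 has a limit of the assay and not a number, so the full size of the step stays unknown: the limit of > 10000 nM in this assay, at which 1 of the 4 values shown sits.

The compounds shown leave open whether the loss follows from any added group on this oxygen or specifically from the carboxylic acid end of carboxymethyl. A small ethyl group, a methyl ester or an amine-bearing chain at the same oxygen could separate these two readings.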